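Chloro-to-methyl swap across two amide series

A few compounds are considered here, and "the series" means these few. Any claim that something is new, unique, unknown or untested is made for them only; others in the source may bear on it.

Compound 2 `Cc1cc(-c2nc3cc(Cl)ccc3o2)ccc1NC(=O)CN1CCN(CCN(C)C)CC1` and compound 1 `Cc1ccc2oc(-c3ccc(NC(=O)CN4CCN(CCN(C)C)CC4)c(C)c3)nc2c1` share one amide side chain and differ only in the group on the fused core. In a functional assay on HepG2 cells (Homo sapiens) for cytotoxicity, read by MTT assay, with a stated time of 24 h (on this read-out lower numbers stand for stronger inhibition and higher numbers for weaker inhibition), compound 2 gives 3880 nM, while compound 1 gives 12800 nM. The change between them, (methyl in place of chloro on an aromatic carbon), shows as a 3.3-fold higher number from compound 2 to compound 1 (0.52 log units; beyond the scatter).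

Compound 3 `Cc1cc(-c2nc3cc(Cl)ccc3o2)ccc1NC(=O)CCl` carries the chloroacetamide in place of that side chain; the difference between the core of compound 3 and the core of compound 2 is not broken down here. In this assay compound 3 gives 35000 nM, the highest number among the three measured compounds.

Compound 4 `Cc1ccc2oc(-c3ccc(NC(=O)CCl)c(C)c3)nc2c1` relates to compound 3 exactly as compound 1 relates to compound 2: methyl in place of chloro on an aromatic carbon. The place of the change is described in the same words in both pairs, so it is taken as the same change. Among the measured compounds shown here, with only one measured instance of it, the expectation for compound 4 rests on that single step, and on the assumption that the chloroacetamide series responds like the side-chain series, which nothing here confirms or denies.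

From compound 3 to compound 4 the step is expected to be about a 2.9-fold higher number from compound 3 to compound 4 (0.46 log units; beyond the scatter), in line with a 3.3-fold higher number from compound 2 to compound 1 (0.52 log units; beyond the scatter). In this assay compound 4 is therefore estimated at 100000 nM, most plausibly between 40000 nM and 250000 nM; a number this high may also be reported only as a limit of the assay.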

Compound 4, half-maximal inhibitory concentration: 54800 nM
Compound 4: the middle estimate sits 1.8-fold (0.26 log units) above what was measured; low and high end bracket the measured number.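

In this assay, methyl in place of chloro on an aromatic carbon gives a 1.6-fold higher number from compound 3 to compound 4 (0.19 log units; within the scatter), so on the chloroacetamide pair the change does not stand clear of the scatter by itself. Set beside the earlier pair, the two steps point the same way and cannot be told apart in size: the same change on two cores in this assay, a 3.3-fold higher number (0.52 log units; beyond the scatter) from compound 2 to compound 1 and a 1.6-fold higher number (0.19 log units; within the scatter) from compound 3 to compound 4, 2.1-fold (0.32 log units) apart, within the scatter of two such steps This shows that the direction of the change carries over between these two pairs and gives no sign that the side chain alters its size, but it does not fix a size for the change, since only one of the two steps lies beyond the scatter, and two pairs cannot establish a rule for the series or show why the numbers move.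

Still open, from the compounds shown here alone, is whether other groups on the same aromatic carbon, such as fluoro, methoxy or trifluoromethyl, would follow chloro or methyl in this read-out. Going by these compounds, it is also open whether the same change would hold on a third side chain, for example one ending in a carboxylic acid or a longer chain carrying a primary amine.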